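Series notes: replacing the triazolyl arm of compound 1

The source may hold more compounds than are shown below. What is called first, only, known or untested is meant among the compounds shown, and "the series" means these compounds.

For the measured compounds named here, compound 1 `O=C1c2c[n+]([O-])c3ccccc3c2C(=O)c2c1c1ccccc1n2Cc1cn(C[C@H](O)CO)nn1` is one of three compounds so far measured in a functional assay on MCF7 cells (Homo sapiens) for cytotoxicity, read by MTT assay, with a stated time of 72 h; a higher number here means a weaker inhibitor, a lower number a stronger inhibitor. In this assay compound 1 gives > 1000 nM, which is a limit of the assay and not a number, as stated by the limit of > 1000 nM in this assay, at which 1 of the 3 values shown sits. Compound 2 `CC1(C)O[C@@H](CO)[C@H](Cn2cc(Cn3c4c(c5ccccc53)C(=O)c3c[n+]([O-])c5ccccc5c3C4=O)nn2)O1` gives 690 nM in this assay, and compound 3 `O=C1c2c[n+]([O-])c3ccccc3c2C(=O)c2c1c1ccccc1n2Cc1cn([C@H]2C[C@H](O)[C@@H](CO)O2)nn1` gives 530 nM. The steps away from compound 1 are floors only: an at least 1.4-fold lower number from compound 1 to compound 2 (0.16 log units; that floor lies within the scatter) and an at least 1.8-fold lower number from compound 1 to compound 3 (0.27 log units; that floor lies within the scatter). Between the two numbered compounds the step is a 1.3-fold lower number from compound 2 to compound 3 (0.11 log units; within the scatter). Compound 1 therefore stands at the limit, with no number of its own, and its neighbours sit within the scatter of that floor.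

Compound 4 `CN(C)CCCCn1c2c(c3ccccc31)C(=O)c1c[n+]([O-])c3ccccc3c1C2=O` is not yet measured. It differs from compound 1 in this way: 3-(dimethylamino)propyl in place of 1-(2,3-dihydroxypropyl)-1H-1,2,3-triazol-4-yl on a saturated chain carbon bound to an aromatic nitrogen. Going by the values given here, no measured step removes the triazole ring; the steps from compound 1 to compound 2 and from compound 1 to compound 3 only reshape the hydroxylated arm and give floors within the scatter. Among the compounds with values here, nothing among the measured steps sets a direction for this change. The estimate for compound 4 is 600 nM, expected to fall between 150 nM and 3000 nM. This estimate for compound 4 means an expected step of an at least 1.6-fold lower number from compound 1 to compound 4 (0.22 log units; that floor lies within the scatter).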

Compound 4, half-maximal inhibitory concentration: 220 nM
Compound 4: the middle estimate sits 2.7-fold (0.44 log units) above what was measured; measured number inside the range.
By their numbers in this assay, from the lowest: compound 4; then compounds 3 and 2 (each within the scatter of the next). At a limit, above all of these: compound 1.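

For the compounds shown here, at this position, on a saturated chain carbon bound to an aromatic nitrogen, putting 3-(dimethylamino)propyl in place of 1-(2,3-dihydroxypropyl)-1H-1,2,3-triazol-4-yl gives the first step in this assay that lies beyond the scatter: an at least 4.5-fold lower number from compound 1 to compound 4 (0.65 log units; beyond the scatter). The earlier steps shown here from compound 1 kept the triazole ring and reshaped only the hydroxylated arm, and their floors stayed within the scatter, so this position now shows that a change of the whole arm can be read in this assay. In this assay compound 1 gives > 1000 nM, which is a limit of the assay and not a number, so the step is a floor and its full size stays unknown: the limit of > 1000 nM in this assay, at which 1 of the 4 values shown sits.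

The change removes the triazole ring and the two hydroxyl groups and brings in the dimethylamino group all at once, so the compounds shown do not tell these parts apart. A plain butyl chain without the amine, or a triazole arm carrying a dimethylamino group, would separate them, and a shorter or longer chain ending in the same amine would show whether the chain length matters.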